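The compounds below may be only part of what the source reports. "The series", "measured", "known", "first", "only" and "open" are said of these compounds alone.

In an ADME assay on BaF3 cells (Mus musculus) for cytotoxicity, read by CellTiter-Glo and CCK-8 assay, with a stated time of 72 h (a lower number here means a stronger inhibitor of growth, a higher number a weaker inhibitor of growth), compound 1 (`C=CC(=O)NCc1ccc(C(=O)Nc2ccc(C)c(Nc3nccc(-c4cccnc4)n3)c2)cc1`) gives > 10000 nM, which is a limit and not a number. Compound 3 (`C=CC(=O)NCc1cccc(C(=O)Nc2ccc(C)c(Nc3nccc(-c4cccnc4)n3)c2)c1`) gives > 10000 nM, also a limit. Compound 1 thus stands at the limit of > 10000 nM in this assay, at which 2 of the 3 values shown sit. Compound 2 (`C=CS(=O)(=O)NCc1ccc(C(=O)Nc2ccc(C)c(Nc3nccc(-c4cccnc4)n3)c2)cc1`) gives 7710 nM, a measured number.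

Compound 4 (`CCC(=O)N(CCN(C)C)Cc1ccc(C(=O)Nc2ccc(C)c(Nc3nccc(-c4cccnc4)n3)c2)cc1`) carries (2-(dimethylamino)ethyl)(propanoyl)amino in place of the (vinylcarbonyl)amino of compound 1, on a saturated chain carbon bound to an aromatic carbon: (2-(dimethylamino)ethyl)(propanoyl)amino in place of (vinylcarbonyl)amino on a saturated chain carbon bound to an aromatic carbon.

Going by the values given here, only one measured step touches this part of the molecule, the swap of vinylcarbonyl for vinylsulfonyl on an amine nitrogen, and it is an at least 1.2-fold lower number from compound 1 to compound 2 (0.11 log units; that floor lies within the scatter). Among the compounds with values here, that is a different change from the one in compound 4, so it gives only loose guidance. Within the data shown here, since compound 2 at 7710 nM is the only number available, no step beyond the scatter is expected in this assay, and no direction can be called with confidence. The estimated step is a number no higher from compound 1 to compound 4 (the limit leaves the size open). For compound 4 the expected value is 10000 nM, with an estimated range from 4000 nM to 25000 nM.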

Compound 4, concentration for 50% growth inhibition: > 10000 nM
Compound 4: a limit, no number; the forecaster's own chance of this, stated with the estimate: 60%; the middle value lies on the limit itself.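

Replacing the (vinylcarbonyl)amino with the larger (2-(dimethylamino)ethyl)(propanoyl)amino, on a saturated chain carbon bound to an aromatic carbon, removes the vinyl double bond and the amide hydrogen, yet compound 4 still gives only a limit, not a number, in this assay: the limit of > 10000 nM in this assay, at which 3 of the 4 values shown sit. Going by these compounds alone, the one readable step is an at least 1.2-fold higher number from compound 2 to compound 4 (0.11 log units; that floor lies within the scatter), so no real change can be claimed from it. The step that starts at compound 1 has a limit at both ends and cannot be read.

From the compounds shown here alone, whether an amine without the propanoyl group, a carboxylic acid or a longer chain at this place would give a measured number in this assay remains open. Going by these compounds, how the compounds sitting at the limit rank among themselves also remains open.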